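A few compounds are considered here, and "the series" means these few. Any claim that something is new, unique, unknown or untested is made for them only; others in the source may bear on it.

Compound 1, with the structure `O=[N+]([O-])c1ccc2[nH]cc(C(c3ccc(Br)cc3)c3c[nH]c4ccc([N+](=O)[O-])cc34)c2c1`, and compound 2, with the structure `O=[N+]([O-])c1ccc(C(c2c[nH]c3ccc([N+](=O)[O-])cc23)c2c[nH]c3ccc([N+](=O)[O-])cc23)cc1`, share a core and differ in one place: nitro in place of bromo on an aromatic carbon. In a functional assay on HeLa cells (Homo sapiens) for inhibition, read by MTT assay, with a stated time of 48 h (on this read-out higher numbers stand for weaker inhibition and lower numbers for stronger inhibition), compound 1 gives a value that is a limit of the assay, > 100000 nM. In this assay compound 2 also gives a limit, > 100000 nM. Because both sit at the limit of > 100000 nM in this assay, at which 2 of the 3 values shown sit, the step that the two limits leave unreadable from compound 1 to compound 2 cannot be read as a number.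

Compound 3, with the structure `OC[C@H]1O[C@@H](n2cc(C(c3ccc(Br)cc3)c3cn([C@@H]4O[C@H](CO)[C@@H](O)[C@H](O)[C@H]4O)c4ccc(Br)cc34)c3cc(Br)ccc32)[C@H](O)[C@@H](O)[C@@H]1O`, has a different core, and the difference between the two cores is not broken down here. In this assay, among the compounds with values here, compound 3 gives 27000 nM, the only true number among the three measured compounds.

Compound 4, with the structure `O=[N+]([O-])c1ccc(C(c2cn([C@@H]3O[C@H](CO)[C@@H](O)[C@H](O)[C@H]3O)c3ccc(Br)cc23)c2cn([C@@H]3O[C@H](CO)[C@@H](O)[C@H](O)[C@H]3O)c3ccc(Br)cc23)cc1`, has not yet been measured. It differs from compound 3 in the same change already seen between compound 1 and compound 2: nitro in place of bromo on an aromatic carbon. The place is described in the same words for both pairs, so this is the same change. The measured step gives no size to carry over, since both of its ends are limits. The expectation for compound 4 therefore rests only on the value of compound 3, 27000 nM, and on the smallness of the change. The step from compound 3 to compound 4 is expected to be about a 1.1-fold higher number from compound 3 to compound 4 (0.05 log units; within the scatter), within the usual scatter. Compound 4 is therefore estimated at 30000 nM in this assay, with a likely range from 9000 nM to 100000 nM.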

Compound 4, half-maximal inhibitory concentration: 30000 nM
Compound 4: middle estimate and measured number agree at the digits printed; low and high end bracket the measured number.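

On the core of compound 3, going from 4-bromophenyl to 4-nitrophenyl gives a 1.1-fold higher number from compound 3 to compound 4 (0.05 log units; within the scatter) in this assay, so on this core the two groups cannot be told apart in this read-out. Within the data shown here, the same change on the core of compound 1 cannot be read as a step, because compound 1 and compound 2 both give a limit of the assay rather than a number: the limit of > 100000 nM in this assay, at which 2 of the 4 values shown sit. Carrying the change from one core to the other therefore remains untested: only one readable pair exists, and it shows neither that the step has the same size on both cores nor why it is so small here.

The compounds shown leave open whether a different group at this place on the phenyl ring, such as an amine or a carboxylic acid, would shift the number on the core of compound 3 by more than the usual scatter. They also leave open which of the several differences between the core of compound 1 and the core of compound 3 matters for the read-out, since no pair shown isolates any one of those differences.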